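Aminopyrazole amidine series: methylpiperazine on the anilide ring

A few compounds are considered here, and "the series" means these few. Any claim that something is new, unique, unknown or untested is made for them only; others in the source may bear on it.

Among the compounds with values here, compound 1 `N=C(Nc1ccccc1)c1cc2c(-c3ccccc3)n[nH]c2c(NC2CCCCC2)n1` stands lowest of the three numbers so far; in a functional assay on PC-3 cells (Homo sapiens) for cytotoxicity, read by MTT assay, with a stated time of 72 h (on this read-out lower numbers stand for stronger inhibition and higher numbers for weaker inhibition), compound 1 gives 1730 nM. Compound 2 `N=C(Nc1ccccc1)c1cc2c(-c3ccccc3)n[nH]c2cn1` gives 23000 nM, and compound 3 `N=C(Nc1cccc(C(F)(F)F)c1)c1cc2c(-c3ccccc3)n[nH]c2c(NC2CCCCC2)n1` gives 25000 nM. Both changes from compound 1 cost a lot: a 13-fold higher number from compound 1 to compound 2 (1.12 log units; beyond the scatter) on removing the cyclohexylamino group, and a 14-fold higher number from compound 1 to compound 3 (1.16 log units; beyond the scatter) on adding trifluoromethyl.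

Compound 4 `CN1CCN(c2ccc(NC(=N)c3cc4c(-c5ccccc5)n[nH]c4c(NC4CCCCC4)n3)cc2)CC1` differs from compound 1 by 4-methylpiperazin-1-yl in place of hydrogen on an aromatic carbon. Within the data shown here, the step that bears on it is the one to compound 3, where a group entering the same six-membered aromatic ring of carbon only gave a 14-fold higher number from compound 1 to compound 3 (1.16 log units; beyond the scatter); that group and the group entering here are not alike, so the size of that step is only a warning, not a template. Among the measured compounds shown here, no measured step shows a 4-methylpiperazin-1-yl group anywhere. The expectation is therefore a weakening within a modest margin, with wide uncertainty, and the estimated step is a 1.6-fold higher number from compound 1 to compound 4 (0.21 log units; within the scatter). Compound 4 is expected at about 2800 nM, in the range 600 nM to 13000 nM.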

Compound 4, half-maximal inhibitory concentration: 4630 nM
For compound 4 the middle estimate is 1.7-fold (0.22 log units) below the measured one; the measured number falls inside the stated range.
By their numbers in this assay, from the lowest: compound 1; then compound 4; then compounds 2 and 3 (each within the scatter of the next).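

In this assay, 4-methylpiperazin-1-yl in place of hydrogen on an aromatic carbon, para to a large group, gives a 2.7-fold higher number from compound 1 to compound 4 (0.43 log units; beyond the scatter) and so still costs potency, though the step is modest. Within the data shown here, this six-membered aromatic ring of carbon only therefore accepts a substituent with a six-membered non-aromatic ring at this place while keeping compound 4 ahead of compounds 2 and 3, whereas the only earlier change on this ring gave a 14-fold higher number from compound 1 to compound 3 (1.16 log units; beyond the scatter), a large step. Nothing available on the compounds accounts for the size of either step.

From the compounds shown here alone, it remains open whether a morpholine or a dimethylamino group on the same carbon would sit closer to compound 1. Also open, going by these compounds, is whether the step would keep its size with hydrogen in place of cyclohexylamino.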